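The compounds below may be only part of what the source reports. "The series", "measured", "known", "first", "only" and "open" are said of these compounds alone.

Measured so far:
compound 1 `COc1ccc(CNCc2c(OC)cc(Oc3cccc(Nc4ccccc4)c3)cc2OC)cc1` — 2650 nM
compound 2 `CNCc1c(OC)cc(Oc2cccc(Nc3ccccc3)c2)cc1OC` — 8930 nM

In a functional assay on HCT-15 cells (Homo sapiens) for inhibition, read by MTT assay, with a stated time of 72 h (a higher number here means a weaker inhibitor, a lower number a stronger inhibitor), compound 2 gives 8930 nM, the highest of the two numbers measured; its nearest neighbour is compound 1, which in this assay gives 2650 nM. For the measured compounds named here, the one measured step bears directly on the question: a 3.4-fold higher number from compound 1 to compound 2 (0.53 log units; beyond the scatter) shows what removing the aryl-bearing group from the amine-bound chain carbon does.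

Compound 3 `COc1cc(Oc2cccc(Nc3ccccc3)c2)cc(OC)c1CN[C@H](C)c1ccccc1` differs from compound 2 as follows: 1-phenylethyl in place of methyl on an amine nitrogen. An aryl-bearing substituent thus returns, now on the amine nitrogen rather than on the neighbouring chain carbon, so the change runs in the opposite sense to the step from compound 1 to compound 2, and the number for compound 3 is expected to fall by a comparable amount, an estimate that means a 3.0-fold lower number from compound 2 to compound 3 (0.47 log units; beyond the scatter). Going by the values given here, since only one step is available, the expectation is loosely held. Compound 3 is therefore estimated at 3000 nM in this assay, with a range of 1200 nM to 7500 nM.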

Compound 3, half-maximal inhibitory concentration: 7550 nM
The estimate for compound 3 lay 2.5-fold (0.40 log units) below the measured number; measured number outside the range, above it.
By their numbers in this assay, from the lowest: compound 1; then compounds 3 and 2 (each within the scatter of the next).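

In this assay the exchange of methyl for 1-phenylethyl on the amine nitrogen gives a 1.2-fold lower number from compound 2 to compound 3 (0.07 log units; within the scatter) so an aromatic ring carried on this nitrogen is not enough on its own to move the number. The 4-methoxybenzyl group of compound 1 separates from 1-phenylethyl at the same position, with a 2.8-fold higher number from compound 1 to compound 3 (0.45 log units; beyond the scatter) and so, of the three substituents, only 4-methoxybenzyl stands apart from the others. No measurement bears on the reason for this difference.

Compound 1 and compound 3 differ at once in the methoxy group, the branching methyl and the defined stereocentre, so a plain benzyl group on the amine nitrogen would be needed to tell these features apart. The mirror-image 1-phenylethyl group would show whether the stereocentre matters at this position.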